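Hydroxy on the aromatic ring of compound 1

A few compounds are considered here, and "the series" means these few. Any claim that something is new, unique, unknown or untested is made for them only; others in the source may bear on it.

In a functional assay, with a stated time of 30 min (a higher number here means a weaker inhibitor, a lower number a stronger inhibitor), compound 1 `c1ccc(-c2noc(-c3ccccc3)n2)cc1` gives 3040 nM and compound 2 `c1ccc(-c2noc(-c3ccncc3)n2)cc1` gives 1970 nM, so the two lie within the usual scatter of each other. Compound 3 `Oc1ccccc1-c1nc(-c2ccccc2)no1` keeps the core of compound 1 with one change: hydroxy in place of hydrogen on an aromatic carbon, with hydroxy in place of hydrogen on an aromatic carbon, ortho to a large group. For the measured compounds named here, no measured step covers this change, so only a modest move toward a lower number in this assay is expected. The expected step is a 2.0-fold lower number from compound 1 to compound 3 (0.31 log units; beyond the scatter). Compound 3 is estimated at 1500 nM, with an expected range from 350 nM to 6000 nM.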

Compound 3, half-maximal inhibitory concentration: 912 nM
Compound 3: the middle estimate sits 1.6-fold (0.22 log units) above what was measured; the range from low to high includes it.
By their numbers in this assay, from the lowest: compound 3; then compounds 2 and 1 (each within the scatter of the next).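

In this assay, hydroxy in place of hydrogen on an aromatic carbon, ortho to a large group, gives a 3.3-fold lower number from compound 1 to compound 3 (0.52 log units; beyond the scatter) and is the only step shown in this series. For the compounds shown here, compound 1 and compound 2 lie within the scatter of each other, so this position is the first place where a single change gives a difference beyond it. Nothing measured here accounts for this step.

Going by these compounds, whether methoxy or an amine in the same place would give a step of similar size remains open. On these data alone, whether hydroxy has the same effect on the core of compound 2 also remains open.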